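The compounds below may be only part of what the source reports. "The series", "measured", "known", "first", "only" and "open" are said of these compounds alone.

Compound 2 `O[C@@H]1Cc2ccccc2N[C@H](c2ccccc2Cl)C1` carries a chloro group on the pendant phenyl ring of the shared core. In an ADME assay on Vero cells (Chlorocebus sabaeus) for cytotoxicity, read by MTT assay, with a stated time of 72 h (a lower number here means that less compound is tolerated, a higher number that more compound is tolerated), compound 2 gives > 300000 nM, which is a limit of the assay rather than a measured number. The related compound 1 `O[C@@H]1Cc2ccccc2N[C@H](c2ccccc2)C1` lacks that chloro group. In this assay compound 1 gives > 300000 nM, again a limit. Compound 3 `O[C@@H]1Cc2ccccc2N[C@H](c2ccccc2F)C1` carries a fluoro group in place of the chloro group. In this assay compound 3 gives > 300000 nM, also a limit. The steps a step that the two limits leave unreadable from compound 1 to compound 2, a step that the two limits leave unreadable from compound 1 to compound 3 and a step that the two limits leave unreadable from compound 2 to compound 3 therefore cannot be read, because the limit of > 300000 nM in this assay, at which 3 of the 3 values shown sit, holds all three values at the same ceiling.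

Compound 4 `Cc1ccc2c(c1)C[C@@H](O)C[C@@H](c1ccccc1Cl)N2` differs from compound 2 by methyl in place of hydrogen on an aromatic carbon. Among the compounds with values here, no measured step involves a change on the fused ring, so the three unreadable steps offer only indirect guidance: every variation tried so far on the pendant phenyl ring left the compounds tolerated up to the highest concentration tested. On that basis the step that the limit leaves unreadable from compound 2 to compound 4 is expected to stay within the scatter, with a high chance that only a limit is reported again. The estimate for compound 4 in this assay is 400000 nM, within a range from 200000 nM to 1000000 nM.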

Compound 4, half-maximal cytotoxic concentration: 82400 nM
Compound 4: the middle estimate sits 4.9-fold (0.69 log units) above what was measured, outside the stated range (below it).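

In this assay, within the data shown here, methyl in place of hydrogen on an aromatic carbon of the fused ring, meta to a fused ring and para to a fused ring, gives an at least 3.6-fold lower number from compound 2 to compound 4 (0.56 log units; beyond the scatter), the first change here with a readable size and the first to show that this part of the shared core can lower the tolerated concentration. That size is only a minimum: one end of the step is a limit, so the real step could be larger. The three steps among the compounds that differ on the pendant phenyl ring cannot be read, so nothing can be said about how that ring compares with the fused ring, because all three values sit at one ceiling: the limit of > 300000 nM in this assay, at which 3 of the 4 values shown sit.

Methyl is the only group shown at this place, so it remains open whether a longer alkyl chain, a methoxy group or a carboxylic acid on the same aromatic carbon would lower the number further or leave it unchanged. Also open, on these data alone, is whether methyl would lower the number to a similar extent on the core of compound 1, which lacks the chloro group.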